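The compounds below may be only part of what the source reports. "The series", "measured", "known", "first", "only" and "open" are said of these compounds alone.

Compound 1 `COC(=O)c1sc2cc(-c3cnn(C)c3)cnc2c1N` carries a 1-methyl-1H-pyrazol-4-yl group on the shared core. In a functional assay on MCF7 cells (Homo sapiens) for inhibition, read by sulforhodamine B assay, with a stated time of 48 h (on this read-out higher numbers stand for weaker inhibition of growth and lower numbers for stronger inhibition of growth), compound 1 gives only a limit, > 150000 nM. Compound 2 `COC(=O)c1sc2cc(-c3ccc(C(F)(F)F)cc3)cnc2c1N` likewise returns only a limit in this assay, > 150000 nM. Compound 1 thus stands at the limit of > 150000 nM in this assay, at which 2 of the 2 values shown sit, with no number to rank it against anything. Compound 3 `COC(=O)c1sc2cc(-c3ccccc3N)cnc2c1N` differs from compound 1 by 2-aminophenyl in place of 1-methyl-1H-pyrazol-4-yl on an aromatic carbon. For the measured compounds named here, no measured step covers a change of this kind, so in this assay no movement beyond the scatter is expected, and a further limit remains the likelier outcome. Compound 3 is estimated at 200000 nM, within 60000 nM to 700000 nM; the expected step that the limit leaves unreadable from compound 1 to compound 3 is judged to stay within the scatter.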

Compound 3, concentration for 50% growth inhibition: 4200 nM
The estimate for compound 3 lay 48-fold (1.68 log units) above the measured number; measured number below the stated range.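

This aromatic carbon on the shared core tolerates no single outcome: in this assay, 2-aminophenyl in place of 1-methyl-1H-pyrazol-4-yl gives an at least 35-fold lower number from compound 1 to compound 3 (1.55 log units; beyond the scatter). Compound 3 thus supplies the only real number in the series, so the substituent at this position can move growth inhibition out of the limit: the limit of > 150000 nM in this assay, at which 2 of the 3 values shown sit.

The change swaps the ring and introduces the amine together, so the compounds shown do not separate the two. On these data alone, whether an unsubstituted phenyl, or a hydroxyl or methoxy group in place of the amine, would retain the step remains open.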